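A few compounds are considered here, and "the series" means these few. Any claim that something is new, unique, unknown or untested is made for them only; others in the source may bear on it.

Measured in a functional assay on NCI-H460 cells (Homo sapiens) for antiproliferative activity, read by MTT assay, with a stated time of 48 h; on this read-out lower numbers stand for stronger inhibition and higher numbers for weaker inhibition:
- compound 1 `CCCCCCCCO[C@@H]1O[C@@H](C)[C@H](OC(=O)CCCCC)[C@@H](O[C@@H]2O[C@@H](C)[C@H](OC(C)=O)[C@@H](OC(=O)C(C)C)[C@H]2OC(C)=O)[C@H]1O`: 47000 nM
- compound 2 `CCCCCCCCO[C@@H]1O[C@@H](C)[C@H](OC(=O)CCCCC)[C@@H](O[C@@H]2O[C@@H](C)[C@H](OC(C)=O)[C@@H](OC(=O)C(C)(C)C)[C@H]2OC(C)=O)[C@H]1O`: 141000 nM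
- compound 3 `CCCCCCCCO[C@@H]1O[C@@H](C)[C@H](OC(=O)CCCCC)[C@@H](O[C@@H]2O[C@@H](C)[C@H](OC(C)=O)[C@@H](OC(=O)CCC)[C@H]2OC(C)=O)[C@H]1O`: 32000 nM

Compound 3 stands at the low end of this set, but not alone there. The nearest step is a 1.5-fold lower number from compound 1 to compound 3 (0.17 log units; within the scatter), and the furthest is a 4.4-fold lower number from compound 2 to compound 3 (0.64 log units; beyond the scatter).

Compound 4 `CCCCCCCCO[C@@H]1O[C@@H](C)[C@H](OC(=O)CCCCC)[C@@H](O[C@@H]2O[C@@H](C)[C@H](OC(C)=O)[C@@H](OC(=O)CC(C)C)[C@H]2OC(C)=O)[C@H]1O` has this difference: methyl in place of hydrogen on a saturated chain carbon bound to two saturated chain carbons. In words, propyl becomes isobutyl. Within the data shown here, the closest precedent is a 3.0-fold higher number from compound 1 to compound 2 (0.48 log units; beyond the scatter), where methyl also replaced hydrogen, but on a carbon bound to a carbonyl carbon and two saturated chain carbons. The change here sits on a different carbon, so a smaller effect is expected in this assay. The expected change is a 1.3-fold higher number from compound 3 to compound 4 (0.12 log units; within the scatter). For compound 4 the estimated value is 42000 nM, with an expected range from 20000 nM to 90000 nM.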

Compound 4, half-maximal inhibitory concentration: 79000 nM
Compound 4: middle estimate off by 1.9-fold (0.27 log units), on the low side; measured number inside the range.
By their numbers in this assay, from the lowest: compounds 3, 1, 4 and 2 (each within the scatter of the next, the first and the last beyond it).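

Methyl in place of hydrogen also raises the number on a saturated chain carbon bound to two saturated chain carbons, where propyl becomes isobutyl, with a 2.5-fold higher number from compound 3 to compound 4 (0.39 log units; beyond the scatter). The earlier compounds shown here showed this change only on a carbon bound to a carbonyl carbon, and the two steps now match: the same change on two cores in this assay, a 3.0-fold higher number (0.48 log units; beyond the scatter) from compound 1 to compound 2 and a 2.5-fold higher number (0.39 log units; beyond the scatter) from compound 3 to compound 4, 1.2-fold (0.08 log units) apart, within the scatter of two such steps Isobutyl itself is not separated from its neighbours, with a 1.7-fold higher number from compound 1 to compound 4 (0.23 log units; within the scatter) and a 1.8-fold lower number from compound 2 to compound 4 (0.25 log units; within the scatter).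

The compounds shown leave open how a longer chain such as pentyl, or an amine on the chain, would read at this position.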